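The source may report more compounds than this note shows. Statements on the series, on what has been measured and on what is new or still open speak of the compounds shown alone.

Three compounds with a shared core were examined in a functional assay on the whole organism (Tail, strain ICR) with Mus musculus as the target, in the tail flick test, with a stated time of 150 min, at a dose of 25 umol/kg by the oral route; a lower number here means a weaker effect, a higher number a stronger effect of the compound at the dose given. Compound 1 `C[C@H](NC(=O)CN(c1nc(Cl)nc2[nH]cnc12)C1CC1)C(=O)O` gives 14.7%. Compound 2 `NC(=O)C[C@H](NC(=O)CN(c1nc(Cl)nc2[nH]cnc12)C1CC1)C(=O)O` gives 7.51%. Compound 3 `CC(C)C[C@H](NC(=O)CN(c1nc(Cl)nc2[nH]cnc12)C1CC1)C(=O)O` gives 9.13%. All three differ only in the group on the saturated chain carbon two bonds along the chain from an amide-type nitrogen and a carbonyl carbon, and every step among them stays within the scatter: a number 7.2 percentage points lower from compound 1 to compound 2 (within the scatter), a number 5.6 percentage points lower from compound 1 to compound 3 (within the scatter), and a number 1.6 percentage points higher from compound 2 to compound 3 (within the scatter). Compound 3 thus sits between the other two on the numbers shown, with its nearest neighbour compound 2 and its furthest neighbour compound 1, neither gap beyond the scatter.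

Compound 4 `CC[C@H](C)[C@H](NC(=O)CN(c1nc(Cl)nc2[nH]cnc12)C1CC1)C(=O)O` has not yet been measured. It differs from compound 3 in one place: sec-butyl in place of isobutyl on a saturated chain carbon bound to an amide-type nitrogen and a carbonyl carbon. Among the measured compounds shown here, no measured step exchanges one branched chain for another of the same size at this position, but the three steps already seen, each within the scatter, show this position to be tolerant of change in this assay. The change from compound 3 to compound 4 is therefore expected to give no step beyond the scatter, a number 0.9 percentage points higher from compound 3 to compound 4 (within the scatter). Compound 4 is estimated to give 10%, within a range from 2% to 20%.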

Compound 4, a percentage reported as activity, at one dose (the size of the read-out at that dose, not a potency): 6.71%
For compound 4 the middle estimate is 3.3 percentage points above the measured one; measured number inside the range.
By their numbers in this assay, from the lowest: compounds 4, 2, 3 and 1 (each within the scatter of the next).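

In this assay, the exchange of isobutyl for sec-butyl, the same atoms joined differently with one defined stereocentre added, gives a number 2.4 percentage points lower from compound 3 to compound 4 (within the scatter), so this rearrangement of the chain, the first of its kind in the series, does not move the read-out beyond the scatter. Sec-butyl also stays within the scatter of the carbamoylmethyl group, with a number 0.8 percentage points lower from compound 2 to compound 4 (within the scatter), and of methyl, with a number 8 percentage points lower from compound 1 to compound 4 (within the scatter), so the four compounds now show no step beyond the scatter at this position, whether the chain is branched at the carbon bound to this position or one carbon further out. Nothing measured here accounts for the size of these steps.

As far as these compounds go, it remains open whether any other group on this saturated chain carbon would give a step beyond the scatter, such as a benzyl group, a longer chain ending in an amine, or a chain ending in a carboxylic acid. From the compounds shown here alone, it is equally open whether the opposite configuration at the new stereocentre of sec-butyl, or an ester in place of the carboxylic acid of the shared core, would change the read-out at this dose.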